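A few compounds are considered here, and "the series" means these few. Any claim that something is new, unique, unknown or untested is made for them only; others in the source may bear on it.

Measured in a functional assay on A549 cells (Homo sapiens) for antiproliferative activity, read by MTT assay, with a stated time of 72 h; on this read-out higher numbers stand for weaker inhibition and lower numbers for stronger inhibition:
- compound 1 `CCN(CC)CCn1cccc1/C=N/NC(=O)Nc1ccc(Oc2ccnc3[nH]ccc23)cc1`: 3570 nM
- compound 2 `O=C(N/N=C/c1cccn1CCCN1CCCCC1)Nc1ccc(Oc2ccnc3[nH]ccc23)c(F)c1`: 2850 nM
- compound 3 `O=C(N/N=C/c1cccn1CCCN1CCCC1)Nc1ccc(Oc2ccnc3[nH]ccc23)c(F)c1`: 2010 nM

Compound 2, at 2850 nM, lies within the usual scatter of both other compounds, so the three numbers show no real separation. Compound 4 `O=C(N/N=C/c1cccn1CCCN1CCCCC1)Nc1ccc(Oc2ccnc3[nH]ccc23)cc1` differs from compound 2 by one change: hydrogen in place of fluoro on an aromatic carbon. Among the measured compounds shown here, no measured pair isolates this change. For the measured compounds named here, the only measured step, a 1.4-fold lower number from compound 2 to compound 3 (0.15 log units; within the scatter), concerns a different place, the ring on the chain, and it is small. Compound 1 also carries no fluoro, but its chain differs too, so it gives only loose guidance. No step beyond the scatter is therefore expected in this assay. The estimated step is a 1.1-fold higher number from compound 2 to compound 4 (0.02 log units; within the scatter). For compound 4 the expected value is 3000 nM, with a range from 1500 nM to 6000 nM.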

Compound 4, half-maximal inhibitory concentration: 1560 nM
Compound 4: middle estimate off by 1.9-fold (0.28 log units), on the high side; low and high end bracket the measured number.
By their numbers in this assay, from the lowest: compounds 4, 3, 2 and 1 (each within the scatter of the next, the first and the last beyond it).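

The change from fluoro to hydrogen on this aromatic carbon can now be read directly: in this assay it gives a 1.8-fold lower number from compound 2 to compound 4 (0.26 log units; within the scatter) and so shows no clear effect of the fluoro. Changing the chain end, with (piperidin-1-yl)methyl in place of diethylamino on the saturated chain carbon, gives a 2.3-fold lower number from compound 1 to compound 4 (0.36 log units; beyond the scatter) as a modest step. No supporting measurement explains either result. On these data alone, whether chloro or methoxy on that aromatic carbon would give a similar number remains open.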